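Ester chain variation in the compound 1 series

The compounds below may be only part of what the source reports. "The series", "measured", "known", "first", "only" and "open" are said of these compounds alone.

Measured so far:
compound 1 `CC1=C(C(=O)OCC(C)C)C(c2ccoc2)NC(=O)N1` — 326 nM
compound 2 `CC1=C(C(=O)OCC(C)C)C(c2cccs2)NC(=O)N1` — 2130 nM
compound 3 `CCCC(=O)C1=C(C)NC(=O)NC1c1ccco1` — 807 nM

In an assay on membranes from HEK293 cells for displacement of a labelled ligand from adenosine receptor A2b (Homo sapiens), read by scintillation counting, with a stated time of 30 min (a higher number here means a weaker inhibitor, a lower number a stronger inhibitor), compound 1 stands lowest of the three numbers. The nearest number is that of compound 3, which differs from compound 1 at another place. In this assay compound 3 gives 807 nM. The furthest is compound 2, reached by a 6.5-fold higher number from compound 1 to compound 2 (0.82 log units; beyond the scatter).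

Compound 4 `CC1=C(C(=O)OCC2CCC2)C(c2ccoc2)NC(=O)N1` has not yet been measured. It differs from compound 1 by cyclobutyl in place of isopropyl on a saturated chain carbon bound to an oxygen next to a carbonyl group.

Within the data shown here, none of the measured steps touches this part of the molecule. Among the measured compounds shown here, the one step that is resolved, a 6.5-fold higher number from compound 1 to compound 2 (0.82 log units; beyond the scatter), concerns the group on the saturated ring carbon and says nothing about the chain bound to the oxygen next to the carbonyl group. The values of compound 1 and compound 3 likewise do not isolate this change. The exchange is small: a three-carbon chain leaves and a four-carbon ring enters, with no donors, acceptors or charge changed. With nothing in the series pointing to a shift, no step beyond the scatter is expected in this assay in either direction.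

Compound 4 is therefore estimated at 320 nM, with a range of 130 nM to 800 nM. The step this estimate implies, a 1.0-fold lower number from compound 1 to compound 4 (0.01 log units; within the scatter), is expected to lie within the scatter.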

Compound 4, inhibition constant: 739 nM
The estimate for compound 4 lay 2.3-fold (0.36 log units) below the measured number; the measured number falls inside the stated range.
By their numbers in this assay, from the lowest: compound 1; then compounds 4 and 3 (each within the scatter of the next); then compound 2.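

In this assay, the place on a saturated chain carbon bound to an oxygen next to a carbonyl group now has its first resolved step, with cyclobutyl in place of isopropyl giving a 2.3-fold higher number from compound 1 to compound 4 (0.36 log units; beyond the scatter). Both groups carry no hydrogen-bond donors, no hydrogen-bond acceptors and no net charge, so this place responds even to an exchange of carbon groups alone, read one bond further out as isobutyl to cyclobutylmethyl. No measured information on the origin of this step is available.

The single step combines the entry of a four-membered ring with the gain of a carbon, and the compounds shown do not separate the two, leaving open how an open chain of the same size, such as n-pentyl, or a smaller ring, such as cyclopropyl, would read in this assay. Also open, on these data alone, are whether an amine or a carboxylic acid at the end of this chain is tolerated, and whether the same exchange gives a comparable step when thiophen-2-yl replaces furan-3-yl on the saturated ring carbon.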